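The source may hold more compounds than are shown below. What is called first, only, known or untested is meant among the compounds shown, and "the series" means these compounds.

In a functional assay on BV-2 cells (Mus musculus), read by Griess assay, with a stated time of 24 h (a lower number here means a stronger inhibitor, a higher number a weaker inhibitor), compound 1 `CC1COC2(C=CC(=O)C=C2)N(c2ccccc2)C1=O` gives 1220 nM while compound 2 `O=C1C=CC2(C=C1)OCC(Cc1ccccc1)C(=O)N2c1ccccc1` gives 570 nM as the lower of the two numbers, which makes compound 2 the stronger inhibitor so far. The next compound, compound 3 `O=C1C=CC2(C=C1)OCC(Cc1ccc(F)cc1)C(=O)N2c1ccccc1`, alters the benzyl group of compound 2 to 4-fluorobenzyl, with fluoro in place of hydrogen on an aromatic carbon. Among the compounds with values here, the only measured step (a 2.1-fold lower number from compound 1 to compound 2 (0.33 log units; beyond the scatter)) put a phenyl in place of hydrogen on a saturated chain carbon and stayed modest even with a whole ring added. Within the data shown here, no measured pair shows what a fluoro does here, so this smaller change is expected to give no step beyond the scatter in this assay for now. The estimated value for compound 3 is 520 nM with an expected range from 240 nM to 1100 nM in this measurement. This estimate means an expected 1.1-fold lower number from compound 2 to compound 3 (0.04 log units; within the scatter) overall.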

Compound 3, half-maximal inhibitory concentration: 400 nM
The estimate for compound 3 lay 1.3-fold (0.11 log units) above the measured number, and the stated range covers the measured number.
By their numbers in this assay, from the lowest: compounds 3 and 2 (each within the scatter of the next); then compound 1.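

In this assay, a fluoro on an aromatic carbon of the benzyl group, para to a large group, gives a 1.4-fold lower number from compound 2 to compound 3 (0.15 log units; within the scatter) and so does not clearly separate the two compounds. This position therefore accepts one fluorine atom in place of hydrogen, but the data show no clear gain from that swap. Against compound 1, the 4-fluorophenyl group gives a 3.1-fold lower number from compound 1 to compound 3 (0.48 log units; beyond the scatter) as a modest step, so the difference from compound 1 remains with the fluoro present; no measurement here explains these results.

Going by these compounds, whether a chlorine, a methoxy group or an amine at this same carbon would move the number beyond the scatter remains open. On these data alone, it is also open whether a fluoro elsewhere on this ring would read the same.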